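Chloro for methoxy on the sulfonamide-bound ring

A few compounds are considered here, and "the series" means these few. Any claim that something is new, unique, unknown or untested is made for them only; others in the source may bear on it.

Of the compounds shown here, three sharing one core have been tested in a functional assay on M21 cells (Homo sapiens) for antiproliferative activity, read by sulforhodamine B assay, with a stated time of 48 h; a lower number here means a stronger inhibitor, a higher number a weaker inhibitor. Compound 1 `CCCCOc1ccc(NS(=O)(=O)c2ccc(N3CCNC3=O)cc2)cc1` carries a butoxy group on the ring attached to the sulfonamide nitrogen and gives 580 nM in this assay. Compound 2 `O=C1NCCN1c1ccc(S(=O)(=O)Nc2ccc(C3CCCCC3)cc2)cc1` replaces that group with a cyclohexyl; in this assay compound 2 reaches only the limit of > 1000 nM, so no number is known for it. Compound 3 `COc1ccccc1NS(=O)(=O)c1ccc(N2CCNC2=O)cc1` bears a 2-methoxyphenyl on the sulfonamide nitrogen and gives 300 nM in this assay, a figure that sits within the usual scatter of the number for compound 1, so the two cannot be ranked.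

Compound 4 `O=C1NCCN1c1ccc(S(=O)(=O)Nc2cccc(Cl)c2)cc1` differs from compound 3 in one place: 3-chlorophenyl in place of 2-methoxyphenyl on a sulfonamide nitrogen. Among the measured compounds shown here, the only measured step, an at least 1.7-fold higher number from compound 1 to compound 2 (0.23 log units; that floor lies within the scatter), concerns a different substituent on the same aryl ring and runs against a limit (the limit of > 1000 nM in this assay, at which 1 of the 3 values shown sits), so it offers no direct guide to swapping a methoxy for a chlorine or to moving the group around the ring. With nothing pointing clearly either way, the expectation for compound 4 is a step of about a 1.7-fold higher number from compound 3 to compound 4 (0.22 log units; within the scatter), which is small against the scatter. Compound 4 is therefore estimated at 500 nM in this assay, with a range from 150 nM to 2000 nM.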

Compound 4, half-maximal inhibitory concentration: 25 nM
For compound 4 the middle estimate is 20-fold (1.30 log units) above the measured one; the whole stated range lies above it.
By their numbers in this assay, from the lowest: compound 4; then compounds 3 and 1 (each within the scatter of the next). At a limit, above all of these: compound 2.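

In this assay the swap on the sulfonamide nitrogen gives a 12-fold lower number from compound 3 to compound 4 (1.08 log units; beyond the scatter), the first step among these compounds that can be read as lying beyond the scatter, so the choice of aryl group on this nitrogen can matter a great deal while the rest of the shared core stays the same. The change is a double one, however: 2-methoxyphenyl leaves and 3-chlorophenyl enters, so the kind of substituent and its place on the ring alter together, and this single step cannot assign the gain to either one. Nothing measured here explains why the number falls so sharply, and the only accompanying note, on the limit reached by compound 2, does not bear on this change.

A 3-methoxyphenyl or a 2-chlorophenyl on the same nitrogen would each alter only one of those two features, so what either would give remains the clearest open question. On these data alone, it also remains open how far the result extends to other groups on this ring, such as a bromine, a nitrile, an amine or a carboxylic acid.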